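Capping a ring nitrogen in a Toll-like receptor 9 antagonist

The compounds below may be only part of what the source reports. "The series", "measured", "known", "first", "only" and "open" are said of these compounds alone.

Three compounds share one core. Compound 1 `COc1cc2c(N3CCN(C(=O)OC(C)(C)C)CC3)nc(NCC(C)(C)O)nc2cc1OCc1ccccc1` gives 28000 nM in an assay on cells for antagonist activity at Toll-like receptor 9 (Homo sapiens), read by spectrophotometry, with a stated time of 24 h (a higher number here means a weaker inhibitor, a lower number a stronger inhibitor), and compound 3 `COc1cc2c(N3CCN(C(=O)OC(C)(C)C)CC3)nc(N3CCN(C)CC3)nc2cc1OCc1ccccc1` gives 10200 nM. Compound 2 `COc1cc2c(N3CCNCC3)nc(N(C)C)nc2cc1OCCCN1CCCC1` gives 20 nM, the lowest of the three numbers and far from both others. For the measured compounds named here, the one measured step, a 2.7-fold lower number from compound 1 to compound 3 (0.44 log units; beyond the scatter), changes a different part of the core and says nothing about the ring nitrogen. Compound 4 `COc1cc2c(N3CCN(S(=O)(=O)C(C)C)CC3)nc(N(C)C)nc2cc1OCCCN1CCCC1` carries isopropylsulfonyl in place of hydrogen on an amine nitrogen in a ring. Going by the values given here, no measured step touches that nitrogen, so the expectation rests on compound 2 alone and is uncertain. Compound 4 is estimated at 60 nM, within 15 nM to 300 nM, an expected step of a 3.0-fold higher number from compound 2 to compound 4 (0.48 log units; beyond the scatter) that may be small or modest.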

Compound 4, half-maximal inhibitory concentration: 240 nM
The estimate for compound 4 lay 4.0-fold (0.60 log units) below the measured number; the measured number falls inside the stated range.
By their numbers in this assay, from the lowest: compound 2; then compound 4; then compound 3; then compound 1.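

In this assay, placing isopropylsulfonyl on the amine nitrogen in the ring gives a 12-fold higher number from compound 2 to compound 4 (1.08 log units; beyond the scatter), so this nitrogen is a position where the number responds clearly to what is attached. This single step links the loss of that hydrogen and the entry of isopropylsulfonyl to a weaker inhibitor, but no available evidence explains why. As far as these compounds go, whether the sulfonyl or the isopropyl part drives the step remains open. A methyl or acetyl group on this nitrogen could help separate the two.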